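This account rests on a few compounds, and the source may have more. Where it says the series, first, only, none or still open, it means among the compounds named here.

Measured in an ADME assay on THP-1 cells (Homo sapiens) for cytotoxicity, read by flow cytometry and propidium iodide staining, with a stated time of 72 h (a higher number here means a weaker inhibitor, a lower number a stronger inhibitor), so far:
Compound 1 `COc1cccc(-c2oc3ccc(N)cc3c(=O)c2O)c1` gives 2000 nM as its value
Compound 2 `Nc1ccc2oc(-c3cccc(C(F)(F)F)c3)c(O)c(=O)c2c1` gives 2000 nM as its value

Compound 2 stands at 2000 nM in this assay and is level with compound 1 at the digits given. Compound 3 (`COc1c(-c2cccc(C(F)(F)F)c2)oc2ccc(N)cc2c1=O`) differs from compound 2 in one place (methyl in place of hydrogen on an oxygen on an aromatic ring), which turns hydroxy to methoxy. Among the compounds with values here, only one measured step exists (no change at the digits printed from compound 1 to compound 2 (within the scatter)). That step put trifluoromethyl in place of methoxy on an aromatic carbon, so it bears only indirectly on a change on an oxygen on an aromatic ring. Within the data shown here, no measured pair tests methyl in place of hydrogen on that oxygen. With so little evidence, the expected step (a 1.5-fold higher number from compound 2 to compound 3 (0.18 log units; within the scatter)) stays within the scatter. Its slight lean toward a higher number, meaning a weaker inhibitor, is a tentative judgement and not a measured trend. The estimated value for compound 3 is 3000 nM with an expected range from 1000 nM to 10000 nM. That width reflects how little the two measured compounds can show about this change.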

Compound 3, half-maximal inhibitory concentration: 33000 nM
For compound 3 the middle estimate is 11-fold (1.04 log units) below the measured one; the whole stated range lies below it.
By their numbers in this assay, from the lowest: compounds 1 and 2 (each within the scatter of the next); then compound 3.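

Turning hydroxy into methoxy is the first change in this short series that moves the number in this assay: it gives a 17-fold higher number from compound 2 to compound 3 (1.22 log units; beyond the scatter), whereas trifluoromethyl in place of methoxy on an aromatic carbon gave no change at the digits printed from compound 1 to compound 2 (within the scatter). The hydrogen on this oxygen therefore matters far more to the reading than the earlier pair could reveal, since replacing it with a methyl, just one added heavy atom, shifts compound 3 clearly toward the weaker end of the scale, although this rests on a single pair of compounds. Nothing in the available data accounts for why this small change has such a large effect.

Whether the same methyl would cause a similar step on compound 1, which carries methoxy rather than trifluoromethyl on its aromatic ring, remains open. It is also unknown whether an ethyl group, a longer chain or an acetyl group on that oxygen would give a number closer to that of compound 2 or compound 3, or one beyond both.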